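This account rests on a few compounds, and the source may have more. Where it says the series, first, only, none or still open, it means among the compounds named here.

Measured so far:
compound 1, `COc1ccc(C(=O)/C=C/c2ccc(Br)cc2)c2c1C=CC(C)(C)O2`, > 10000 nM;
compound 2, `COc1ccc(C(=O)/C=C/c2ccc(N(c3ccccc3)c3ccccc3)cc2)c2c1C=CC(C)(C)O2`, > 10000 nM.

In a functional assay on SK-OV-3 cells (Homo sapiens) for antiproliferative activity, read by MTT assay, with a stated time of 24 h (on this read-out higher numbers stand for weaker inhibition and lower numbers for stronger inhibition), compound 1 reaches only the limit of the assay, > 10000 nM, and no number. Compound 2 likewise stops at the limit, > 10000 nM. For the measured compounds named here, compound 1 thus stands at the limit, and the second value shown sits there too (the limit of > 10000 nM in this assay, at which 2 of the 2 values shown sit), so the two measured compounds give no step from which a trend could be read. Compound 3, `COc1ccc(C(=O)/C=C/c2cccs2)c2c1C=CC(C)(C)O2`, differs from compound 1 by thiophen-2-yl in place of 4-bromophenyl on a double-bonded chain carbon bound to a double-bonded chain carbon. Since both measured compounds rest at the limit, no step beyond the scatter is expected from this change, in either direction. Compound 3 is therefore expected to stay at the limit as well, with an estimate of 15000 nM, in the range 5000 nM to 50000 nM. The step that the limit leaves unreadable from compound 1 to compound 3 is expected to lie within the scatter.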

Compound 3, half-maximal inhibitory concentration: > 10000 nM
Compound 3 gave a limit, no number (the forecaster's own chance of this, stated with the estimate: 75%); the middle value does not contradict the limit.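

For the compounds shown here, no step from compound 1 to compound 3 can be read in this assay because both compounds give only a limit: the limit of > 10000 nM in this assay, at which 3 of the 3 values shown sit.

The compounds shown leave open whether thiophen-2-yl and 4-bromophenyl differ at all in this assay and what change to the shared core would give a number instead of a limit.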